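The source may report more compounds than this note shows. Statements on the series, on what has been measured and on what is new or still open speak of the compounds shown alone.

Measured compounds in a functional assay on A549 cells (Homo sapiens) for cytotoxicity, read by CellTiter-Blue, with a stated time of 72 h; on this read-out higher numbers stand for weaker inhibition and lower numbers for stronger inhibition: compound 1 `C/C=C(\C)[C@H]1OC(=O)[C@@H](C)NC(=O)[C@H]([C@@H](C)CC)NC(=O)CN(C)C(=O)[C@@H](Cc2ccccc2)N(C)C(=O)[C@@H](C)NC(=O)[C@@H](CC(C)C)OC(=O)/C(C)=C/C[C@H](O)[C@@H]1C` gives 1050 nM; compound 2 `C/C=C(\C)[C@H]1OC(=O)[C@@H](C)NC(=O)[C@H]([C@@H](C)CC)NC(=O)CN(C)C(=O)[C@@H](Cc2ccccc2)N(C)C(=O)[C@@H](C)NC(=O)[C@@H](CC(C)C)OC(=O)/C(C)=C/C[C@H](OCSC)[C@@H]1C` gives 4340 nM; compound 3 `C/C=C(\C)[C@H]1OC(=O)[C@@H](C)NC(=O)[C@H]([C@@H](C)CC)NC(=O)CN(C)C(=O)[C@@H](Cc2ccc(Cl)cc2)N(C)C(=O)[C@H](C)NC(=O)[C@@H](CC(C)C)OC(=O)/C(C)=C/C[C@H](O)[C@@H]1C` gives 0.00001 nM.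

Compound 2 differs from compound 1 by one change, ((methylsulfanyl)methyl in place of hydrogen on an oxygen on a saturated carbon), and this change made a step of a 4.1-fold higher number from compound 1 to compound 2 (0.62 log units; beyond the scatter). Compound 3 carries a different core: the difference between the core of compound 1 and the core of compound 3 is not broken down here, and what the two values show is that compound 3 sits at a far lower number than compound 1 in this assay.

Compound 4 `C/C=C(\C)[C@H]1OC(=O)[C@@H](C)NC(=O)[C@H]([C@@H](C)CC)NC(=O)CN(C)C(=O)[C@@H](Cc2ccc(Cl)cc2)N(C)C(=O)[C@H](C)NC(=O)[C@@H](CC(C)C)OC(=O)/C(C)=C/C[C@H](OCSC)[C@@H]1C` is not yet measured. It stands to compound 3 as compound 2 stands to compound 1: the change is (methylsulfanyl)methyl in place of hydrogen on an oxygen on a saturated carbon, and it is the same change, at the same place, that appears twice among these compounds. Within the data shown here, since the only precedent for it is the step of a 4.1-fold higher number from compound 1 to compound 2 (0.62 log units; beyond the scatter), compound 4 is expected to lie a similar distance from compound 3, a step of about a 4.0-fold higher number from compound 3 to compound 4 (0.60 log units; beyond the scatter). On that basis compound 4 is estimated at 0.00004 nM, most likely between 0.000005 nM and 0.001 nM.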

Compound 4, half-maximal inhibitory concentration: 0.73 nM
Beside the measured number, compound 4's estimate is 18000-fold (4.26 log units) below it, and the stated range ends below it.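

On the core of compound 3, in this assay, placing (methylsulfanyl)methyl on the oxygen in place of hydrogen gives a 73000-fold higher number from compound 3 to compound 4 (4.86 log units; beyond the scatter), so the change moves the number in the same direction on this core as on the core of compound 1. The direction carries over between the two cores, but the size of the step does not: the same change on two cores in this assay, a 4.1-fold higher number (0.62 log units; beyond the scatter) from compound 1 to compound 2 and a 73000-fold higher number (4.86 log units; beyond the scatter) from compound 3 to compound 4, 18000-fold (4.25 log units) apart, beyond the scatter of two such steps With only these two pairs, and with the difference between the two cores not broken down here, the values do not show which feature of the core governs the size of the step, nor how large the step would be on any further core.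

The compounds shown leave open how other groups on the same oxygen, such as a methyl ether or an acetyl ester, would behave on each core. They also leave open whether such groups would give a small step on the core of compound 1 and a large one on the core of compound 3.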